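This account rests on a few compounds, and the source may have more. Where it says the series, first, only, none or still open, it means among the compounds named here.

Measured compounds:
- Compound 1 `COC(=O)c1ccc(-c2ccc(N3CCN(C)CC3)c(NC(=O)c3cc(N)c(F)c(C)c3Cl)c2)cc1` — in an ADME assay on HUVEC cells (Homo sapiens) for cytotoxicity, read by MTT assay, with a stated time of 24 h (a higher number here means a weaker inhibitor, a lower number a stronger inhibitor), compound 1 gives "not determined" (no result reported).
- Compound 2 `Cc1c(F)c(N)cc(C(=O)Nc2cc(-c3ccc(NC(=O)C4CCN(C)CC4)cc3)ccc2N2CCN(C)CC2)c1Cl` — in this assay compound 2 gives > 100000 nM.

Compound 2 is reported only as a limit of the assay, not as a number; this is the one value with a sign among the two entries shown, as the limit of > 100000 nM in this assay, at which 1 of the 2 values shown sits, records. Compound 3 `Cc1c(F)c(N)cc(C(=O)Nc2cc(-c3ccc(NC(=O)C4CCOCC4)cc3)ccc2N2CCN(C)CC2)c1Cl` has not yet been measured in this assay. It differs from compound 2 in one place: oxan-4-yl in place of 1-methylpiperidin-4-yl on a carbonyl carbon. Going by the values given here, no measured pair with a single change is available to size this step. The shared core and the remaining groups stay the same, so compound 3 is expected to sit close to compound 2, with a step from compound 2 to compound 3 estimated at a number no higher from compound 2 to compound 3 (the limit leaves the size open), that is, none beyond the usual scatter. For compound 3 the estimate is 100000 nM, with a range from 40000 nM to 300000 nM, and the result is more likely than not to come back as a limit again.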

Compound 3, half-maximal inhibitory concentration in the HUVEC assay: > 100000 nM
Compound 3 was reported as a limit; the forecaster's own chance of this, stated with the estimate: 70%; the middle value sits exactly at the limit.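

In the HUVEC assay, compound 2 gives > 100000 nM, which is a limit of the assay. In the HUVEC assay, compound 3 gives > 100000 nM, which is also a limit of the assay. Going by these compounds alone, no step between them can be read. The compounds shown leave open whether oxan-4-yl in place of 1-methylpiperidin-4-yl on a carbonyl carbon changes the number in the HUVEC assay at all. In a physicochemical assay for solubility, using potentiometric titration, at pH 7.4 (a higher number here means a more soluble compound, a lower number a less soluble compound), compound 2 gives 3900 nM and compound 3 gives 126000 nM.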